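Solubility notes: benzylic replacements for the pyridin-4-yl group

The compounds below may be only part of what the source reports. "The series", "measured", "known", "first", "only" and "open" are said of these compounds alone.

Measured so far:
compound 1, `COc1cccc(NC(=O)c2nnn(Cc3ccncc3)c2N)c1`: < 12000 nM
compound 2, `COc1cccc(NC(=O)c2nnn(Cc3ccc(C(C)C)cc3)c2N)c1`: 14000 nM
compound 3, `COc1cccc(NC(=O)c2nnn(Cc3ccccc3)c2N)c1`: 16000 nM

In a physicochemical assay for solubility, read by nephelometry, at pH 7.4 (on this read-out higher numbers stand for higher solubility and lower numbers for lower solubility), compound 1 reaches only the limit of the assay, (the limit of < 12000 nM in this assay, at which 1 of the 3 values shown sits), so its value is a bound and not a number. Compound 2 gives 14000 nM in this assay, and compound 3 gives 16000 nM; the step of a 1.1-fold higher number from compound 2 to compound 3 (0.06 log units; within the scatter) lies within the scatter, so the two sit together.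

Compound 4, `COc1cccc(NC(=O)c2nnn(Cc3ccc(SC)cc3)c2N)c1`, has not been measured in this assay. Its change from compound 1 is 4-(methylsulfanyl)phenyl in place of pyridin-4-yl on a saturated chain carbon bound to an aromatic nitrogen. Going by the values given here, the steps that bear on it are the two other exchanges at the same place: an at least 1.1-fold higher number from compound 1 to compound 2 (0.06 log units; that floor lies within the scatter) and an at least 1.3-fold higher number from compound 1 to compound 3 (0.12 log units; that floor lies within the scatter). Both floors lie within the scatter, so each shows at best a small rise from the limit of compound 1 to a numbered value.

Compound 4 is therefore expected to move as an at least 1.1-fold higher number from compound 1 to compound 4 (0.06 log units; that floor lies within the scatter), a small step up from the limit of compound 1, close to compounds 2 and 3. The estimate for compound 4 in this assay is 14000 nM, between 8000 nM and 26000 nM.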

Compound 4, solubility: < 12000 nM
Compound 4: only a limit was reported (the forecaster's own chance of this, stated with the estimate: 35%); middle value at least 1.1-fold (0.06 log units) from the limit.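

With 4-(methylsulfanyl)phenyl in place of pyridin-4-yl, compound 4 gives only a limit in this assay, not a number, so a carbon-only aromatic ring at this place does not by itself lift a compound to a numbered value, and the limit is now shared: the limit of < 12000 nM in this assay, at which 2 of the 4 values shown sit.

Methylsulfanyl in place of hydrogen gives an at least 1.3-fold lower number from compound 3 to compound 4 (0.12 log units; that floor lies within the scatter), and methylsulfanyl in place of isopropyl gives an at least 1.1-fold lower number from compound 2 to compound 4 (0.06 log units; that floor lies within the scatter), so neither exchange is shown to go beyond the scatter. The step between the two limits cannot be read.

Going by these compounds, how far compound 1 and compound 4 truly lie from the limit stays open, and so does their order against each other. Also open, on these data alone, is whether a phenyl carrying a carboxylic acid or a dimethylamino group at this place would read clear of the limit.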